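The compounds below may be only part of what the source reports. "The series", "measured", "known", "first", "only" and "open" are said of these compounds alone.

Compound 3 (`C/C(=C\CC/C(C)=C/CC[C@@H]1[C@@]2(C)CCC(=O)C(C)(C)[C@H]2CC[C@@]1(C)O)CC/C=C(\C)C(=O)OCc1cn(-c2ccccc2)nn1`) carries the plain phenyl group. In an ADME assay on L132 cells (Homo sapiens) for cytotoxicity, read by MTT assay, with a stated time of 48 h (a lower number here means a stronger inhibitor, a higher number a weaker inhibitor), compound 3 gives > 150000 nM, which is a limit and not a number. Compound 1 (`C/C(=C\CC/C(C)=C/CC[C@@H]1[C@@]2(C)CCC(=O)C(C)(C)[C@H]2CC[C@@]1(C)O)CC/C=C(\C)C(=O)OCc1cn(-c2ccc(F)cc2)nn1`), with a 4-fluorophenyl group, gives > 150000 nM, also a limit. Compound 2 (`C/C(=C\CC/C(C)=C/CC[C@@H]1[C@@]2(C)CCC(=O)C(C)(C)[C@H]2CC[C@@]1(C)O)CC/C=C(\C)C(=O)OCc1cn(-c2ccccc2[N+](=O)[O-])nn1`), with a 2-nitrophenyl group, gives > 150000 nM, again a limit. The three measured compounds therefore share one reading: the limit of > 150000 nM in this assay, at which 3 of the 3 values shown sit.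

The next member is compound 4 (`C/C(=C\CC/C(C)=C/CC[C@@H]1[C@@]2(C)CCC(=O)C(C)(C)[C@H]2CC[C@@]1(C)O)CC/C=C(\C)C(=O)OCc1cn(-c2ccccc2Cl)nn1`), reached by chloro in place of hydrogen on an aromatic carbon. This is chloro in place of hydrogen on an aromatic carbon, ortho to a large group, turning phenyl into 2-chlorophenyl.

Among the compounds with values here, two measured steps bear on this change: a step that the two limits leave unreadable from compound 1 to compound 3 and a step that the two limits leave unreadable from compound 2 to compound 3. Neither has a readable size, so they supply no magnitude and no direction for a substituent on this phenyl group. Compound 2 is the closest guide, since its 2-nitrophenyl group still reads > 150000 nM. No step beyond the usual scatter is therefore expected in this assay, and a further limit is the most likely report. The estimated step is a step that the limit leaves unreadable from compound 3 to compound 4. For compound 4 the estimated value is 180000 nM, with an expected range from 90000 nM to 350000 nM.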

Compound 4, half-maximal inhibitory concentration: > 150000 nM
Compound 4: a limit, no number; the forecaster's own chance of this, stated with the estimate: 90%; the middle value lies beyond the limit too.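

In this assay compound 4 gives > 150000 nM, a limit and not a number, so no step can be read between compound 4 and compound 1, compound 2 or compound 3. The compounds shown leave open whether any substituent on this phenyl group changes the cytotoxicity reading at all, as all share one reading: the limit of > 150000 nM in this assay, at which 4 of the 4 values shown sit.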